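This account rests on a few compounds, and the source may have more. Where it says the series, first, only, none or still open, it means among the compounds named here.

For the measured compounds named here, in an ADME assay on a cell-free system (plasma, Homo sapiens) for protein binding, compound 1 (`C[C@@H](Oc1cc2oc(=O)n(CCC(=O)O)c2cc1Cl)c1cccnn1`) gives 68.1%, the higher unbound fraction of the two compounds measured so far. Compound 2 (`C[C@@H](Oc1cc2onc(CCC(=O)O)c2cc1Cl)c1ccc(Cl)cn1`) gives 99.8%, and this gap in unbound fraction lies beyond the scatter. The two compounds differ in more than one place, so the gap cannot be tied to a single structural change.

The next compound is compound 3 (`CCOc1cc2oc(=O)n(CCC(=O)O)c2cc1Cl`), which has hydrogen in place of pyridazin-3-yl on a saturated chain carbon bound to an oxygen on an aromatic ring and a saturated chain carbon.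

Going by the values given here, no measured pair isolates this change, so the expectation is loose. A modest move towards more bound compound is expected in this assay, although a result within the scatter would not be surprising. The estimated size is a 1.6-fold lower unbound fraction from compound 1 to compound 3 (0.20 log units; within the scatter). For compound 3 the expected value is 80%, with an estimated range from 60% to 93%.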

Compound 3, plasma protein binding: 95.8%
The estimate for compound 3 lay 4.8-fold (0.68 log units) (unbound fraction) above the measured number, and the stated range ends below it.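

Taking the pyridazin-3-yl off the saturated chain carbon bound to an oxygen on an aromatic ring and a saturated chain carbon gives the first comparison in the series that differs in one place, and in this assay it reads as a 7.6-fold lower unbound fraction from compound 1 to compound 3 (0.88 log units; beyond the scatter). For the compounds shown here, this position therefore bears on the read-out: with the rest of the core of compound 1 kept, the compound carrying the six-membered aromatic ring with 2 hetero atoms is the one with more free compound, a link that compound 1 and compound 2 could not show, as they differ in more than one place. No measurement at hand accounts for the size of this step.

One pair cannot tell whether this shift belongs to the pyridazin-3-yl itself or would appear with any ring on that carbon, so a phenyl ring or a pyridin-3-yl there would separate the two readings. Going by these compounds, it also remains open whether a non-aromatic group on the same carbon, such as a morpholine or a primary amine, would sit nearer to compound 1 or to compound 3 in this assay.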